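Swapping an amide cap for a sulfonamide cap

A few compounds are considered here, and "the series" means these few. Any claim that something is new, unique, unknown or untested is made for them only; others in the source may bear on it.

In a functional assay on SW-620 cells (Homo sapiens) for cytotoxicity, read by MTT assay, with a stated time of 48 h (on this read-out lower numbers stand for stronger inhibition and higher numbers for weaker inhibition), compound 1 `CCCCCCCCCCCCCCCCCCNC(=O)[C@@H](N)[C@@H](C)O` gives 21400 nM. Compound 2 `CCCCCCCCCCCCCCCCCCNC(=O)[C@@H](NC(=O)c1ccccc1)[C@@H](C)O` gives 200000 nM, and compound 3 `CCCCCCCCCCCCCCCCCCNC(=O)[C@@H](NC(=O)/C=C/c1ccccc1)[C@@H](C)O` gives 200000 nM. On these numbers compound 3 sits level with compound 2 at the weakest end of the three, with compound 1 alone standing apart: a 9.3-fold higher number from compound 1 to compound 3 (0.97 log units; beyond the scatter), and likewise a 9.3-fold higher number from compound 1 to compound 2 (0.97 log units; beyond the scatter). Between the two capped compounds there is no change at the digits printed from compound 2 to compound 3 (within the scatter).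

Compound 4 `CCCCCCCCCCCCCCCCCCNC(=O)[C@@H](NS(=O)(=O)c1ccc(C)cc1)[C@@H](C)O` differs from compound 3 by (4-methylphenyl)sulfonyl in place of (2-phenylethenyl)carbonyl on an amine nitrogen. For the measured compounds named here, the steps that bear on this are the two caps already tried: a benzoyl and a cinnamoyl group on the same amine nitrogen each moved the number the same way, by the same amount, and exchanging one for the other changed nothing. The tosyl group is a third cap of the same size on that nitrogen. There is no measured case in which a sulfonyl cap behaves differently from an acyl cap, so the expectation is a step of no change at the digits printed from compound 3 to compound 4 (within the scatter) in this assay, that is, nothing beyond the scatter.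

Compound 4 is therefore estimated at 200000 nM in this assay, with a range from 90000 nM to 400000 nM.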

Compound 4, half-maximal inhibitory concentration: 32500 nM
The estimate for compound 4 lay 6.2-fold (0.79 log units) above the measured number; the whole stated range lies above it.
By their numbers in this assay, from the lowest: compounds 1 and 4 (each within the scatter of the next); then compounds 2 and 3 (each within the scatter of the next).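

In this assay, the kind of cap on this amine nitrogen turns out to matter, which the two acyl caps alone could not show: (4-methylphenyl)sulfonyl in place of (2-phenylethenyl)carbonyl gives (a 6.2-fold lower number from compound 3 to compound 4 (0.79 log units; beyond the scatter)), and in place of benzoyl it gives (a 6.2-fold lower number from compound 2 to compound 4 (0.79 log units; beyond the scatter)). Putting a cap on the nitrogen therefore does not by itself bring the higher number, as the sulfonyl-capped compound cannot be told apart from the free amine (a 1.5-fold higher number from compound 1 to compound 4 (0.18 log units; within the scatter)). The leaving and entering groups have the same count of heavy atoms and one six-membered aromatic ring each, yet the numbers part, and nothing measured here gives a reason for this.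

A 4-methylbenzoyl cap would help separate the sulfonyl link from the methyl on the ring, while a plain phenylsulfonyl cap would test the methyl on its own. Also open, going by these compounds, is whether the same result holds for a methanesulfonyl cap, which has no ring, or for a compound with a shorter chain on the amide.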